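The source may report more compounds than this note shows. Statements on the series, on what has been measured and on what is new or still open speak of the compounds shown alone.

Measured so far in a functional assay on CCRF-CEM cells (Homo sapiens) for cytotoxicity; a higher number here means that more compound is tolerated, a lower number that less compound is tolerated:
- compound 1, `Cc1nc(C)n2c(=O)[nH]c(=S)[nH]c12`: 526000 nM
- compound 2, `CSC1N=CNc2c(C)ncn21`: 176000 nM

Compound 2 holds the lowest of the two numbers in this assay; compound 1 sits a step above it, and that gap lies beyond the scatter. Going by the values given here, no pair of measured compounds differs in only one place, so no single-change step is known.

Compound 3, `CSC1N=CNc2c(C)nc(C)n21`, differs from compound 2 by methyl in place of hydrogen on an aromatic carbon. Among the compounds with values here, with no measured step of this kind to lean on, the expectation in this assay is a change not beyond the scatter, in no firm direction. For compound 3 the estimate is 180000 nM, with a range from 70000 nM to 450000 nM. The expected step is a 1.0-fold higher number from compound 2 to compound 3 (0.01 log units; within the scatter), essentially flat.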

Compound 3, half-maximal cytotoxic concentration: 440000 nM
Estimate against measurement, compound 3: 2.4-fold (0.39 log units) below, within the range that was stated.
By their numbers in this assay, from the lowest: compound 2; then compounds 3 and 1 (each within the scatter of the next).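

In this assay, methyl in place of hydrogen on this aromatic carbon gives a 2.5-fold higher number from compound 2 to compound 3 (0.40 log units; beyond the scatter). Going by these compounds alone, this is the only single-change step so far, and it shows that the position between two ring nitrogen atoms is not silent: a single added carbon moves the number towards more compound tolerated, by a modest amount that lies beyond the scatter. Nothing at hand gives a reason for this step.

On these data alone, whether the step belongs to methyl alone remains open, since a longer chain such as ethyl, an amine or a carboxylic acid at the same carbon could give a different result. Also open, as far as these compounds go, is whether the same change would give a step of similar size and direction on a different core.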